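This account rests on a few compounds, and the source may have more. Where it says the series, first, only, none or still open, it means among the compounds named here.

Compound 1 `FC(F)(F)c1ccc(CSc2nc(Nc3ccccc3Cl)c3ccccc3n2)cc1`: in a functional assay on MGC-803 cells (Homo sapiens) for cytotoxicity, read by MTT assay, with a stated time of 72 h (on this read-out lower numbers stand for stronger inhibition and higher numbers for weaker inhibition), compound 1 gives > 50000 nM, which is a limit of the assay and not a number.
Compound 2 `COc1ccccc1Nc1nc(SCc2ccc(C(F)(F)F)cc2)nc2ccccc12`: in this assay compound 2 gives > 50000 nM, again a limit and not a number.
Compound 3 `FC(F)(F)c1ccc(CSc2nc(Nc3ccc(C(F)(F)F)cc3)c3ccccc3n2)cc1`: in this assay compound 3 gives 6170 nM.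

Compound 3 is therefore the only one of the three with a measured number; the other two sit at the limit of > 50000 nM in this assay, at which 2 of the 3 values shown sit. Compound 4 `Fc1ccc(Nc2nc(SCc3ccc(C(F)(F)F)cc3)nc3ccccc23)cc1Cl` differs from compound 3 in one place: 3-chloro-4-fluorophenyl in place of 4-(trifluoromethyl)phenyl on a nitrogen on an aromatic ring. Among the compounds with values here, two measured steps touch the same nitrogen. There was an at least 8.1-fold lower number from compound 1 to compound 3 (0.90 log units; beyond the scatter) and an at least 8.1-fold lower number from compound 2 to compound 3 (0.90 log units; beyond the scatter), both exchanges of a 2-substituted phenyl for the 4-(trifluoromethyl)phenyl, and both are only readable as lower bounds since they start from a limit. Within the data shown here, no measured pair compares two phenyl rings substituted away from the nitrogen-bearing carbon, so the size of the step to a 3-chloro-4-fluorophenyl cannot be read from the data. Compound 4 keeps a substituent in the 4-position of the phenyl as compound 3 does, so the step from compound 3 to compound 4 is expected to be a 1.0-fold lower number from compound 3 to compound 4 (0.01 log units; within the scatter), within the scatter. Compound 4 is estimated to give 6000 nM in this assay, between 2000 nM and 20000 nM.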

Compound 4, half-maximal inhibitory concentration: > 50000 nM
Compound 4: a limit, no number; the forecaster's own chance of this, stated with the estimate: 15%; middle value at least 8.3-fold (0.92 log units) away from the limit.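

In this assay, the exchange of 4-(trifluoromethyl)phenyl for 3-chloro-4-fluorophenyl on this nitrogen gives an at least 8.1-fold higher number from compound 3 to compound 4 (0.90 log units; beyond the scatter), so the measurable activity of compound 3 does not survive a change to a ring that carries no substituent of the kind found in compound 1 or compound 2. Within the data shown here, the earlier steps only showed 2-chlorophenyl and 2-methoxyphenyl falling short of 4-(trifluoromethyl)phenyl, whereas this step shows that the position is also sensitive among rings with other substitution, and 4-(trifluoromethyl)phenyl remains the only group here that gives a number. Compound 4 gives a limit and not a number, and the steps to it from compound 1 and from compound 2 cannot be read: the limit of > 50000 nM in this assay, at which 3 of the 4 values shown sit.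

Going by these compounds, it remains open whether the chlorine or the fluorine of the entering ring matters more, as a 3-chlorophenyl or a 4-fluorophenyl on this nitrogen would help to tell. On these data alone, it is also open whether another group in place of the trifluoromethyl, such as a nitrile, would keep a measurable number.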